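This account rests on a few compounds, and the source may have more. Where it says the series, first, only, none or still open, it means among the compounds named here.

Compound 1 `Cc1nc(-c2cnc3ccc(-c4ccc(N)cc4)cc3c2)no1` — in a functional assay on RD cells (Homo sapiens) for inhibition, read by luminescence and ATP content, with a stated time of 72 h (a higher number here means that more compound is tolerated, a lower number that less compound is tolerated), compound 1 gives > 2500 nM, a limit of the assay.
Compound 2 `CCCCc1ccc(-c2ccc3ncc(-c4noc(C(F)(F)F)n4)cc3c2)cc1` — in this assay compound 2 gives > 7400 nM, also a limit of the assay.

Among the measured compounds shown here, compound 2 thus stands at a limit and not at a number; both values shown are limits (the limit of > 2500 nM in this assay, at which 1 of the 2 values shown sits, (the limit of > 7400 nM in this assay, at which 1 of the 2 values shown sits)), so no measured step exists between them and nothing can be said about their order. Compound 3 `CCCCc1ccc(-c2ccc3ncc(-c4noc(C)n4)cc3c2)cc1` is not yet measured. It differs from compound 2 in one place: methyl in place of trifluoromethyl on an aromatic carbon. For the measured compounds named here, no measured pair carries this change, so the expectation rests on compound 2 alone. One expects no step beyond the scatter in this assay, with the estimated step from compound 2 to compound 3 being a step that the limit leaves unreadable from compound 2 to compound 3, and most likely another limit. Compound 3 is estimated at 9000 nM, expected to fall between 3000 nM and 30000 nM.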

Compound 3, half-maximal cytotoxic concentration: > 2500 nM
Compound 3: only a limit was reported (the forecaster's own chance of this, stated with the estimate: 75%); the middle value lies beyond the limit too.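

Among the compounds shown here, compound 3, like compound 1 and compound 2, stands at a limit in this assay, so no step among them can be read. Going by these compounds, whether swapping trifluoromethyl for methyl, or amino for butyl, changes how much compound is tolerated remains open.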